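The source may report more compounds than this note shows. Statements on the series, on what has been measured and on what is new or still open speak of the compounds shown alone.

Compound 3 `CCn1cc(-c2ccnc3[nH]c(C4CCN(CC(=O)N(C)C)CC4)cc23)ccc1=O` carries ethyl on the aromatic nitrogen of the shared core. In an ADME assay on cells (Hepatocyte, Rattus norvegicus) for metabolic stability (on this read-out lower numbers stand for slow clearance and higher numbers for fast clearance), compound 3 gives < 1 uL/min, which is a limit of the assay rather than a number, the limit noted in the limit of < 1 uL/min in this assay, at which 1 of the 3 values shown sits. The two other measured analogues differ from compound 3 only in the group on that nitrogen. Compound 1 `CC(C)Cn1cc(-c2ccnc3[nH]c(C4CCN(CC(=O)N(C)C)CC4)cc23)ccc1=O` gives 6.6 uL/min in this assay, and compound 2 `CN(C)C(=O)CN1CCC(c2cc3c(-c4ccc(=O)n(CCC5CCOCC5)c4)ccnc3[nH]2)CC1` gives 14 uL/min in this assay. Both steps toward the smaller group, an at least 6.6-fold lower number from compound 1 to compound 3 (0.81 log units; beyond the scatter) and an at least 14-fold lower number from compound 2 to compound 3 (1.14 log units; beyond the scatter), run to slower clearance, while a 2.1-fold higher number from compound 1 to compound 2 (0.33 log units; beyond the scatter) is a modest move in the opposite sense. Compound 4 `CN(C)C(=O)CN1CCC(c2cc3c(-c4ccc(=O)n(C5CCC5)c4)ccnc3[nH]2)CC1` differs from compound 3 by cyclobutyl in place of ethyl on an aromatic nitrogen. The group grows from two carbons to four, in the direction that the measured steps join with faster clearance, so the number for compound 4 is expected to leave the limit and rise into the region of compound 1. The expected step is an at least 7.0-fold higher number from compound 3 to compound 4 (0.84 log units; beyond the scatter). For compound 4 the estimate in this assay is 7 uL/min, within a range from 2.5 uL/min to 20 uL/min.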

Compound 4, intrinsic clearance in a liver preparation (reported as CLH), per the amount of preparation that the assay uses: 5.8 uL/min
The estimate for compound 4 lay 1.2-fold (0.08 log units) above the measured number; measured number inside the range.
By their numbers in this assay, from the lowest: compounds 4 and 1 (each within the scatter of the next); then compound 2. At a limit, below all of these: compound 3.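

Cyclobutyl, a ring set directly on the aromatic nitrogen, cannot be told apart from the open isobutyl chain in this assay, with a 1.1-fold lower number from compound 1 to compound 4 (0.06 log units; within the scatter). The same ring gives slower clearance than the 2-(oxan-4-yl)ethyl chain, with a 2.4-fold lower number from compound 2 to compound 4 (0.38 log units; beyond the scatter), yet faster clearance than ethyl, with an at least 5.8-fold higher number from compound 3 to compound 4 (0.76 log units; beyond the scatter), so among the four groups on this nitrogen only ethyl reaches the bottom of the range. Compound 3 stands at a limit of the assay and not at a number, so its step gives only a bound: the limit of < 1 uL/min in this assay, at which 1 of the 4 values shown sits.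

As far as these compounds go, whether slow clearance extends to methyl or cyclopropyl on this nitrogen remains open. So does the effect of an oxygen-bearing group smaller than 2-(oxan-4-yl)ethyl, such as 2-methoxyethyl or oxetan-3-yl.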